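A few compounds are considered here, and "the series" means these few. Any claim that something is new, unique, unknown or untested is made for them only; others in the source may bear on it.

Measured compounds:
compound 1 `COc1ccc(N(C)c2nc(C)nc3ccccc23)cc1C(=O)OCCC[Se]C#N` — 1180 nM
compound 2 `C[Se]c1ccc(N(C)c2nc(C)nc3ccccc23)cc1C` — 7 nM
compound 3 `CN(c1ccc([Se]C#N)cc1)c1nc(C2CC2)nc2ccccc12` — 29 nM

In a functional assay on MDA-MB-231 cells (Homo sapiens) for inhibition, read by MTT assay, with a stated time of 48 h (a higher number here means a weaker inhibitor, a lower number a stronger inhibitor), compound 1 gives 1180 nM, the highest of the three numbers. Compound 3 gives 29 nM, the nearest of the other two, and the gap lies beyond the scatter. Compound 2 gives 7 nM, the furthest from compound 1, again beyond the scatter. Compound 1 is thus the weakest inhibitor of the three on the numbers in hand.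

Compound 4 `COc1ccc(N(C)c2nc(C)nc3ccccc23)cc1C(=O)OCCCC[Se]C#N` is not yet measured. It differs from compound 1 in one place: a group of 4 heavy atoms (2 carbon, 1 nitrogen, 1 selenium; no ring) in place of a group of 3 heavy atoms (1 carbon, 1 nitrogen, 1 selenium; no ring), on a saturated chain carbon, three bonds along the chain from an oxygen next to a carbonyl group. The change is an extension of the saturated chain carrying the selenium-bearing end, with the rest of the molecule held the same. Within the data shown here, no pair of measured compounds shares this kind of change, so there is no step from which its size can be read directly. The change is small, so a step in this assay of no more than the usual scatter is expected, in either direction. Compound 4 is expected to give 1000 nM, with a range from 400 nM to 3000 nM. The expected step of a 1.2-fold lower number from compound 1 to compound 4 (0.07 log units; within the scatter) is within the scatter.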

Compound 4, half-maximal inhibitory concentration: 554 nM
Compound 4: the middle estimate sits 1.8-fold (0.26 log units) above what was measured; the measured number falls inside the stated range.
By their numbers in this assay, from the lowest: compound 2; then compound 3; then compound 4; then compound 1.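

In this assay, among these compounds, the saturated chain carrying the selenium-bearing end is the first place where a single change can be read: a group of 4 heavy atoms (2 carbon, 1 nitrogen, 1 selenium; no ring) in place of a group of 3 heavy atoms (1 carbon, 1 nitrogen, 1 selenium; no ring) gives a 2.1-fold lower number from compound 1 to compound 4 (0.33 log units; beyond the scatter). The step is modest, but it shows that the number responds to chain length at this position and that the longer chain is tolerated. No measurement on hand bears on the reason for this step.

On these data alone, whether a longer chain would extend the step, or an amide in place of the ester would change it, stays open. Steps from compound 1 or compound 4 to compound 2 or compound 3 cannot be read: those pairs differ in more than one place.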